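The source may report more compounds than this note shows. Statements on the series, on what has been measured and on what is new or still open speak of the compounds shown alone.

The series rests on a shared core, seen in compound 1 `O=C1C=COC(/C=C/c2ccccc2)C1`, which in a functional assay on OVCAR-3 cells (Homo sapiens) for inhibition, read by sulforhodamine B assay, with a stated time of 48 h (a higher number here means a weaker inhibitor of growth, a lower number a stronger inhibitor of growth), gives 58.2 uM. Compound 2 `COc1ccc(/C=C/C2CC(=O)C=CO2)cc1` carries a methoxy group on an aromatic carbon, and in this assay compound 2 gives 87.4 uM. Compound 3 `COc1ccc(/C=C/C2CC(=O)C=CO2)cc1OC` adds a second methoxy, and in this assay compound 3 gives 74.3 uM. All three numbers lie within the usual scatter of one another, so compound 3 stands among its neighbours with no separation that can be trusted. The unmeasured compound 4 `COc1cc(/C=C/C2CC(=O)C=CO2)cc(OC)c1OC` differs from compound 3 by methoxy in place of hydrogen on an aromatic carbon. The two earlier steps of the same kind bear directly on it: a 1.5-fold higher number from compound 1 to compound 2 (0.18 log units; within the scatter) and a 1.2-fold lower number from compound 2 to compound 3 (0.07 log units; within the scatter), both within the scatter. On that footing no step beyond the scatter is expected in this assay, in either direction, and the expected step is a 1.0-fold higher number from compound 3 to compound 4 (0.00 log units; within the scatter). The estimate for compound 4 in this assay is therefore 75 uM, with a range from 40 uM to 140 uM.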

Compound 4, concentration for growth inhibition (reported as GI): 85.4 uM
Compound 4: middle estimate off by 1.1-fold (0.06 log units), on the low side, within the range that was stated.
By their numbers in this assay, from the lowest: compounds 1, 3, 4 and 2 (each within the scatter of the next).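

In this assay, the third methoxy group brings a 1.1-fold higher number from compound 3 to compound 4 (0.06 log units; within the scatter). Methoxy in place of hydrogen at this carbon, ortho to a methoxy group and meta to another, therefore leaves no separation that can be trusted, even on a ring already carrying two methoxy groups. Two steps of this change can also be set side by side, and they do not differ by more than the scatter: the same change on two cores in this assay, a 1.5-fold higher number (0.18 log units; within the scatter) from compound 1 to compound 2 and a 1.1-fold higher number (0.06 log units; within the scatter) from compound 3 to compound 4, 1.3-fold (0.12 log units) apart, within the scatter of two such steps.

The compounds shown leave open whether a hydroxyl group, an amine or a carboxylic acid in place of hydrogen on this aromatic ring would move the number beyond the scatter in this assay. They also leave open whether a change to the shared core itself, such as a longer chain between the two rings, would do so.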